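The compounds below may be only part of what the source reports. "The series", "measured", "known", "first", "only" and "open" are said of these compounds alone.

Measured in a functional assay on HeLa cells (Homo sapiens) for antiproliferative activity, read by MTT assay, with a stated time of 72 h; on this read-out lower numbers stand for stronger inhibition and higher numbers for weaker inhibition:
Compound 1 `Nc1nc(N)c2cc(CSC(=S)N3CCN(c4ccc(Cl)cc4)CC3)ccc2n1`: 6990 nM
Compound 2 `Nc1nc(N)c2cc(CSC(=S)N3CCN(c4ccccc4Cl)CC3)ccc2n1`: 4050 nM
Compound 3 `Nc1nc(N)c2cc(CSC(=S)N3CCN(c4ccc(F)cc4)CC3)ccc2n1`: 1840 nM

Compound 3 has the lowest of these three numbers. Compound 4 `Nc1nc(N)c2cc(CSC(=S)N3CCN(c4ccc(F)cc4F)CC3)ccc2n1` differs from it by fluoro in place of hydrogen on an aromatic carbon, which turns 4-fluorophenyl into 2,4-difluorophenyl. Fluoro in place of chloro gave a 3.8-fold lower number from compound 1 to compound 3 (0.58 log units; beyond the scatter), and 4-fluorophenyl in place of 2-chlorophenyl gave a 2.2-fold lower number from compound 2 to compound 3 (0.34 log units; beyond the scatter). Both steps are modest, and both exchange one halogen for another. The closest guide to a substituent at this place is 2-chlorophenyl in place of 4-chlorophenyl, which gave a 1.7-fold lower number from compound 1 to compound 2 (0.24 log units; within the scatter). Going by the values given here, no measured step adds a second halogen to the ring, so no clear direction can be expected in this assay. The expected change is small, with a 1.2-fold higher number from compound 3 to compound 4 (0.08 log units; within the scatter) as the estimated step. For compound 4 the estimated value is 2200 nM, with an expected range of 800 nM to 6000 nM.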

Compound 4, half-maximal inhibitory concentration: 3800 nM
Compound 4: the middle estimate sits 1.7-fold (0.24 log units) below what was measured; the measured number falls inside the stated range.
By their numbers in this assay, from the lowest: compound 3; then compounds 4, 2 and 1 (each within the scatter of the next).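

In this assay, going by these compounds alone, a fluoro group placed ortho to a large group on the 4-fluorophenyl ring gave a 2.1-fold higher number from compound 3 to compound 4 (0.31 log units; beyond the scatter), the first measured step that adds a second halogen, and it went towards weaker inhibition. The 2,4-difluorophenyl group thereby fell within the scatter of both chlorophenyl groups, with a 1.1-fold lower number from compound 2 to compound 4 (0.03 log units; within the scatter) and a 1.8-fold lower number from compound 1 to compound 4 (0.26 log units; within the scatter). Nothing available explains this rise. Still open, from the compounds shown here alone, is whether a lone 2-fluorophenyl group, or a methoxy group or an amine at this place, would move the number the same way.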